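Acrylic acid series: methoxyphenyl variation at the chain carbon

The source may report more compounds than this note shows. Statements on the series, on what has been measured and on what is new or still open speak of the compounds shown alone.

Measured so far:
- compound 1 `CC(=O)n1cc(/C=C(/C(=O)O)c2ccccc2)c2cc(OCc3ccccc3)ccc21`: > 100000 nM
- compound 2 `COc1ccc(OC)c(/C(=C\c2cn(C(C)=O)c3ccc(OCc4ccccc4)cc23)C(=O)O)c1`: 87100 nM
- compound 3 `COc1cc(OC)cc(/C(=C\c2cn(C(C)=O)c3ccc(OCc4ccccc4)cc23)C(=O)O)c1`: 94000 nM

In a functional assay on M14 cells (Homo sapiens) for cytotoxicity, read by MTT assay, with a stated time of 72 h (on this read-out lower numbers stand for stronger inhibition and higher numbers for weaker inhibition), compound 1 gives only a limit, > 100000 nM. Compound 2 gives 87100 nM and compound 3 gives 94000 nM, and compound 3 thus stands as the highest of the two numbers, with compound 2 the nearest, a 1.1-fold higher number from compound 2 to compound 3 (0.03 log units; within the scatter). The steps from the phenyl parent, an at least 1.1-fold lower number from compound 1 to compound 2 (0.05 log units; that floor lies within the scatter) and an at least 1.0-fold lower number from compound 1 to compound 3 (0.02 log units; that floor lies within the scatter), start from a limit of > 100000 nM in this assay, at which 1 of the 3 values shown sits, and so give only floors.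

Compound 4 `COc1ccc(/C(=C\c2cn(C(C)=O)c3ccc(OCc4ccccc4)cc23)C(=O)O)cc1` differs from compound 3 in one place: 4-methoxyphenyl in place of 3,5-dimethoxyphenyl on a double-bonded chain carbon bound to a carbonyl carbon and a double-bonded chain carbon. The measured steps that bear on it are the small ones among compounds 1, 2 and 3, none of which lies beyond the scatter. A change of the methoxy pattern on this phenyl has so far moved the number little, so no step beyond the scatter is expected in this assay, in either direction. Compound 4 is therefore expected to give about 95000 nM, in the range 45000 nM to 200000 nM, an expected step of a 1.0-fold higher number from compound 3 to compound 4 (0.00 log units; within the scatter), with a fair chance that only a limit is returned.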

Compound 4, half-maximal inhibitory concentration: > 100000 nM
Compound 4 gave a limit, no number; the forecaster's own chance of this, stated with the estimate: 35%; at least 1.0-fold (0.02 log units) between middle value and limit.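

Compound 4 gives only a limit in this assay, > 100000 nM, and it is the second limit in the set: the limit of > 100000 nM in this assay, at which 2 of the 4 values shown sit. With 4-methoxyphenyl in place of a dimethoxyphenyl group on this chain carbon, the readable steps are an at least 1.0-fold higher number from compound 3 to compound 4 (0.02 log units; that floor lies within the scatter) and an at least 1.1-fold higher number from compound 2 to compound 4 (0.05 log units; that floor lies within the scatter), both floors that do not separate compound 4 from the dimethoxyphenyl compounds. A third methoxy pattern therefore adds no step beyond the scatter at this position, and the step between the two limits, compound 1 and compound 4, cannot be read.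

From the compounds shown here alone, whether an amine or a hydroxyl group on this phenyl, in place of methoxy, would give a step beyond the scatter in this assay remains open. Going by these compounds, how compound 1 and compound 4 compare with each other also remains open.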